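Phenyl-ether to phenyl-thioether swap on a diamine scaffold

The compounds below may be only part of what the source reports. "The series", "measured", "known", "first", "only" and "open" are said of these compounds alone.

Compound 1 `Nc1cc(N)c2nc(-c3ccccc3)c(Oc3ccc(Cl)c(Cl)c3)nc2c1` was examined in a functional assay on NCI-H23 cells (Homo sapiens) for inhibition, read by sulforhodamine B assay, with a stated time of 48 h; on this read-out lower numbers stand for higher toxicity in this test and higher numbers for lower toxicity in this test. For compound 1 the result is only a limit of the test, < 100000 nM, so where it sits among measured numbers cannot be stated more closely than that (the limit of < 100000 nM in this assay, at which 1 of the 2 values shown sits). Compound 2 `COc1cc(CNc2nc3cc(N)cc(N)c3nc2-c2ccccc2)cc(OC)c1OC` carries a different side group on the shared core, and in this assay compound 2 gives 33900 nM. Among the measured compounds shown here, no step between measured compounds can be drawn here.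

Compound 3 `Nc1cc(N)c2nc(-c3ccccc3)c(Sc3ccc(F)cc3)nc2c1` differs from compound 1 by (4-fluorophenyl)sulfanyl in place of 3,4-dichlorophenoxy on an aromatic carbon. With compound 1 known only as a limit, no direction beyond the scatter is expected for this step, and the estimated step that the limit leaves unreadable from compound 1 to compound 3 is taken as roughly neutral. Compound 3 is therefore expected to give about 45000 nM in this assay, within a range from 12000 nM to 100000 nM.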

Compound 3, concentration lethal to 50% of the cells: 81300 nM
Compound 3: the middle estimate sits 1.8-fold (0.26 log units) below what was measured, within the range that was stated.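

No step from compound 1 to compound 3 can be read, because compound 1 is known in this assay only as a limit: the limit of < 100000 nM in this assay, at which 1 of the 3 values shown sits.

The compounds shown leave open what the sulfur link and the change in ring halogens each contribute on their own.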